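A few compounds are considered here, and "the series" means these few. Any claim that something is new, unique, unknown or untested is made for them only; others in the source may bear on it.

Compound 1 `N#CC1=C(N)Oc2c(c3nc4ccccc4nc3c3ccccc23)C12C(=O)N(Cc1cnnn1-c1ccc([N+](=O)[O-])cc1)c1ccccc12`: in a functional assay on HepG2 cells (Homo sapiens) for antiproliferative activity, read by MTT assay, with a stated time of 48 h (a higher number here means a weaker inhibitor, a lower number a stronger inhibitor), compound 1 reaches only the limit of > 50000 nM, a boundary of the assay and not a number.
Compound 2 `N#CC1=C(N)Oc2c(c3nc4ccccc4nc3c3ccccc23)C12C(=O)N(Cc1cnnn1-c1cccc(S(N)(=O)=O)c1)c1ccccc12`: in this assay compound 2 gives 21500 nM.
Compound 3 `Cc1ccc(C)c(-n2nncc2CN2C(=O)C3(C(C#N)=C(N)Oc4c3c3nc5ccccc5nc3c3ccccc43)c3ccccc32)c1`: in this assay compound 3 again reaches only the limit of > 50000 nM.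

Compound 3 therefore sits among the weakest of the three, at the limit of > 50000 nM in this assay, at which 2 of the 3 values shown sit. Within the data shown here, the only numbered value belongs to compound 2, and the step of an at least 2.3-fold higher number from compound 2 to compound 3 (0.36 log units; beyond the scatter) shows that exchanging the sulfamoylphenyl for the dimethylphenyl weakens the compound. The step that the two limits leave unreadable from compound 1 to compound 3 cannot be read, since both ends are limits.

Compound 4 `N#CC1=C(N)Oc2c(c3nc4ccccc4nc3c3ccccc23)C12C(=O)N(Cc1cnnn1-c1ccc(F)c(Cl)c1)c1ccccc12` differs from compound 3 in one place: 3-chloro-4-fluorophenyl in place of 2,5-dimethylphenyl on an aromatic nitrogen. Among the measured compounds shown here, no measured step involves a halogenated phenyl ring, so the closest guidance is that both compounds without the sulfonamide group, compound 1 and compound 3, stay at the limit. The change to compound 4 keeps the ring free of hydrogen-bond donors and acceptors, as the count above shows, so the expected step is a number no higher from compound 3 to compound 4 (the limit leaves the size open), meaning no move beyond the scatter. Compound 4 is estimated to give 50000 nM in this assay, within a range of 15000 nM to 150000 nM, with a good chance that only a limit is reported.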

Compound 4, half-maximal inhibitory concentration: > 50000 nM
Compound 4: only a limit was reported (the forecaster's own chance of this, stated with the estimate: 60%); the middle value lies on the limit itself.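

Placed on the aromatic nitrogen of the five-membered ring, 3-chloro-4-fluorophenyl behaves like 4-nitrophenyl and 2,5-dimethylphenyl in this assay, so a halogen-bearing ring also gives no numbered value, only the limit of the assay: (the limit of > 50000 nM in this assay, at which 3 of the 4 values shown sit). Among these compounds, exchanging the 3-sulfamoylphenyl of compound 2 for this ring gives an at least 2.3-fold higher number from compound 2 to compound 4 (0.36 log units; beyond the scatter) and adds a second, differently substituted example of losing the only numbered value in the set, so among the four compounds a measurable effect appears only with the sulfamoyl group. The steps among compound 1, compound 3 and compound 4 cannot be read, as each has a limit at both ends, and these three rings therefore cannot be placed in any order.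

From the compounds shown here alone, it remains open whether the sulfamoyl group itself accounts for the numbered value of compound 2, or whether a phenyl ring carrying an amine or a carboxylic acid would also give a number in this assay. A single compound also cannot show whether moving the sulfamoyl group to another place on the ring would change that value.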